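From Acetylphenyl to Benzyl on the Amide-Type Nitrogen

The source may hold more compounds than are shown below. What is called first, only, known or untested is meant among the compounds shown, and "the series" means these compounds.

Compound 2 `COC(=O)c1cc(=O)c2cc(NC(=O)Nc3cccc(C(C)=O)c3)ccc2[nH]1` carries a 3-acetylphenyl group on an amide-type nitrogen of the shared core. In a functional assay on KOPN-8 cells (Homo sapiens) for antiproliferative activity, with a stated time of 72 h (a lower number here means that less compound is needed, a higher number that more compound is needed for the effect), compound 2 gives only a limit, > 8080 nM, and not a number. Its neighbour compound 1 `COC(=O)c1cc(=O)c2cc(NC(=O)Nc3ccc(Cl)c(Cl)c3)ccc2[nH]1`, with 3,4-dichlorophenyl in the same place, likewise reaches only a limit in this assay, namely > 6350 nM. The step that the two limits leave unreadable from compound 1 to compound 2 therefore carries no readable size, because the limit of > 6350 nM in this assay, at which 1 of the 2 values shown sits, and the limit of > 8080 nM in this assay, at which 1 of the 2 values shown sits, both stop short of a number.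

Compound 3 `COC(=O)c1cc(=O)c2cc(NC(=O)NCc3ccccc3)ccc2[nH]1` is the next variation: benzyl in place of 3-acetylphenyl on an amide-type nitrogen. Among the compounds with values here, no measured step bears on this change with a readable size; the single step available is unreadable, and both values shown sit at limits. Nothing in the measured pairs points to a direction, so no step beyond the scatter is expected. The step from compound 2 to compound 3 is thus estimated as a step that the limit leaves unreadable from compound 2 to compound 3. Compound 3 is expected to give about 10000 nM in this assay, between 3000 nM and 40000 nM, with a high chance that this assay again reports only a limit.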

Compound 3, half-maximal effective concentration: > 19500 nM
Compound 3: no number, only a limit (the forecaster's own chance of this, stated with the estimate: 80%); at least 1.9-fold (0.29 log units) between middle value and limit.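

Compound 3, like compound 1 and compound 2, gives only a limit and not a number in this assay, so no step among these three compounds can be read. The compounds shown leave open how benzyl, 3-acetylphenyl and 3,4-dichlorophenyl on the amide-type nitrogen compare, and whether any of these groups on the shared core gives a number in this assay.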